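The compounds below may be only part of what the source reports. "The series", "measured", "known", "first", "only" and "open" are said of these compounds alone.

Compound 1 `O=C1C[C@@H](O[C@H]2O[C@H](CO)[C@@H](O)[C@H](O)[C@H]2O)CN1` gives 89000 nM in a functional assay on RAW264.7 cells (Mus musculus) for inhibition, read by Griess assay, with a stated time of 24 h; on this read-out higher numbers stand for weaker inhibition and lower numbers for stronger inhibition.
Compound 2 `C[C@@H]1O[C@@H](O[C@@H]2CNC(=O)C2)[C@H](O)[C@H](O)[C@H]1O` gives 66900 nM in this assay.
Compound 3 `O=C1C[C@@H](O[C@H]2O[C@H](CO)[C@@H](O)[C@H](O)[C@H]2O)CN1Cc1ccccc1` gives 72500 nM in this assay.

Among these three, compound 3 sits second highest in this assay; its nearest neighbour is compound 2, whose value lies within the scatter of that of compound 3, and compound 1 is the furthest of the three, also within the scatter. Within the data shown here, the one step that can be read off these numbers, a 1.2-fold lower number from compound 1 to compound 3 (0.09 log units; within the scatter), shows that adding the benzyl group to the amide-type nitrogen of the ring leaves the inhibition essentially unchanged.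

Compound 4 `O=C1C[C@H](O[C@H]2O[C@H](CO)[C@@H](O)[C@H](O)[C@@H]2O)CN1Cc1ccccc1` is related to compound 3 as follows: the two compounds have the same atoms and bonds and differ only in configuration as drawn: 2 of 6 stereo elements differ; a stereocentre at a saturated ring carbon is drawn R in compound 3 and S in compound 4; a stereocentre at a saturated ring carbon is drawn R in compound 3 and S in compound 4. Among the measured compounds shown here, no measured pair in this set differs only in configuration, so there is no step that bears directly on this change. What the data do show is that all three measured compounds cluster at weak inhibition, regardless of the sugar or the nitrogen substituent. On that basis the step is expected to be a 1.0-fold higher number from compound 3 to compound 4 (0.01 log units; within the scatter), with no direction that can be argued from the numbers. Compound 4 is therefore estimated to give 75000 nM, within a range from 30000 nM to 200000 nM.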

Compound 4, half-maximal inhibitory concentration: 64000 nM
Compound 4: the middle estimate sits 1.2-fold (0.07 log units) above what was measured; the range from low to high includes it.
By their numbers in this assay, from the lowest: compounds 4, 2, 3 and 1 (each within the scatter of the next).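

In this assay, among these compounds, redrawing two stereocentres at saturated ring carbons from R to S gives a 1.1-fold lower number from compound 3 to compound 4 (0.05 log units; within the scatter), the first step in this set that concerns configuration rather than a substituent. The earlier step, a 1.2-fold lower number from compound 1 to compound 3 (0.09 log units; within the scatter), spoke only to benzyl in place of hydrogen on the amide-type nitrogen; this one shows that, for this benzyl pair, the configuration at these two ring carbons also leaves the inhibition essentially unchanged. The comparison isolates stereochemistry from any other structural difference: the fact that compounds 3 and 4 differ only in the configuration as drawn

Going by these compounds, the two stereocentres change together here, so what either one does alone remains open, as does whether the same configurational change would leave the inhibition unchanged in a compound carrying hydrogen on the amide-type nitrogen. Also open, on these data alone, is whether an amine, a carboxylic acid or a longer chain in place of benzyl on that nitrogen would produce a step beyond the scatter, which neither the benzyl step nor this change of configuration can tell.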